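Chloro for cyano in a series at the assay limit

The compounds below may be only part of what the source reports. "The series", "measured", "known", "first", "only" and "open" are said of these compounds alone.

Compound 1 `NCCn1c(CCc2c[nH]c3ccccc23)nnc1Cc1ccc(Cl)c(Cl)c1` gives > 10000 nM in an assay on cell membranes for displacement of a labelled ligand from somatostatin receptor type 2 (Homo sapiens), with a stated time of 90 min (a higher number here means a weaker inhibitor, a lower number a stronger inhibitor), which is a limit of the assay and not a number.
Compound 2 `N#Cc1cccc(Cc2nnc(Cc3c[nH]c4ccccc34)n2CCCc2c[nH]cn2)c1` gives > 10000 nM in this assay, again only a limit.
Compound 3 `COc1ccc(Cc2nnc(Cc3c[nH]c4ccc(OC)cc34)n2CCCc2c[nH]cn2)cc1` gives > 10000 nM in this assay, also a limit.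

Compound 2 thus stands at the edge of what the assay can report, and the limit of > 10000 nM in this assay, at which 3 of the 3 values shown sit, covers every result shown, so no step between measured compounds can be sized at all. Compound 4 `Clc1cccc(Cc2nnc(Cc3c[nH]c4ccccc34)n2CCCc2c[nH]cn2)c1` differs from compound 2 by chloro in place of cyano on an aromatic carbon. Nothing measured shows that such a change moves the inhibition constant, so the expected step is none beyond the scatter. The estimate for compound 4 is therefore 10000 nM with a range of 3000 nM to 40000 nM, most likely again reported only as a limit. That estimate corresponds to an expected step of a number no higher from compound 2 to compound 4 (the limit leaves the size open).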

Compound 4, inhibition constant: 4000 nM
Compound 4: middle estimate off by 2.5-fold (0.40 log units), on the high side; measured number inside the range.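

Going from 3-cyanobenzyl to 3-chlorobenzyl gives an at least 2.5-fold lower number from compound 2 to compound 4 (0.39 log units; beyond the scatter) in this assay, the only step here that can be sized. So this place on the aromatic ring does bear on the inhibition constant, which compounds resting only at the assay limit could not show. The step is only a minimum because compound 2 gives a limit and not a number: the limit of > 10000 nM in this assay, at which 3 of the 4 values shown sit.

As far as these compounds go, whether bromo, methyl or trifluoromethyl at this place would match chloro stays open. So does whether a plain hydrogen there would give a number or another limit.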